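Removing the chloro: from compound 2 to compound 4

The source may hold more compounds than are shown below. What is called first, only, known or untested is meant among the compounds shown, and "the series" means these compounds.

In a functional assay on BE(2)-C cells (Homo sapiens) for inhibition, read by MTT assay, with a stated time of 72 h (a higher number here means a weaker inhibitor of growth, a lower number a stronger inhibitor of growth), the measured compounds stand as follows:
compound 1 `CC(C)(C)c1ccc(CNCCNS(=O)(=O)c2cc(C(F)(F)F)cc(C(F)(F)F)c2)cc1` gives 14000 nM;
compound 2 `O=S(=O)(NCCCNCc1ccc(Cl)cc1)c1cc(C(F)(F)F)cc(C(F)(F)F)c1` gives 2900 nM;
compound 3 `COc1cccc(CNCCCNS(=O)(=O)c2cc(C(F)(F)F)cc(C(F)(F)F)c2)c1` gives 4500 nM.

Compound 2 has the lowest of the three numbers; compound 3 lies within the scatter of it, and compound 1 lies beyond the scatter above it. Compound 4 `O=S(=O)(NCCCNCc1ccccc1)c1cc(C(F)(F)F)cc(C(F)(F)F)c1` differs from compound 2 by hydrogen in place of chloro on an aromatic carbon. Within the data shown here, the only measured step that touches this ring is a 1.6-fold higher number from compound 2 to compound 3 (0.19 log units; within the scatter), which exchanges one substituent for another rather than removing one, so it bears on the change only loosely. Removing the chloro is expected to give a small step upward, a 1.7-fold higher number from compound 2 to compound 4 (0.24 log units; within the scatter), probably within the scatter. Compound 4 is therefore estimated at 5000 nM, with a range from 2500 nM to 12000 nM.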

Compound 4, concentration for 50% growth inhibition: 12000 nM
The estimate for compound 4 lay 2.4-fold (0.38 log units) below the measured number, within the range that was stated.
By their numbers in this assay, from the lowest: compounds 2 and 3 (each within the scatter of the next); then compounds 4 and 1 (each within the scatter of the next).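

In this assay the bare phenyl ring of compound 4 stands apart from both substituted rings: removing the chloro gives a 4.1-fold higher number from compound 2 to compound 4 (0.62 log units; beyond the scatter) and removing the methoxy gives a 2.7-fold higher number from compound 3 to compound 4 (0.43 log units; beyond the scatter) as a second step beyond the scatter. The earlier exchange of one substituent for the other stayed within the scatter, so only now does a substituent on this ring, whichever of the two, appear to go with the lower number. Nothing at hand explains this difference.

On these data alone, whether a fluoro, methyl or nitrile group on the ring would match the chloro remains open.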